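This account rests on a few compounds, and the source may have more. Where it says the series, first, only, none or still open, it means among the compounds named here.

Measured compounds:
compound 1 `COc1ccc(Cl)cc1C(=O)Nc1ccc(C2=NNC(c3ccccc3[N+](=O)[O-])C2)cc1` in a functional assay on the whole organism (plasma, strain albino) for inhibition, with Rattus norvegicus as the target, with stated times of 1 h and 4 h, at a dose of 50 mg/kg by the oral route (a higher number here means a stronger effect of the compound at the dose given, a lower number a weaker effect), gives 84.5%
compound 2 `COc1ccc(Cl)cc1C(=O)Nc1ccc(C2=NNC(c3ccc([N+](=O)[O-])cc3)C2)cc1` gives 86.3%

Compound 1 gives the lower of the two numbers, and its nearest neighbour is compound 2; the step of a number 1.8 percentage points higher from compound 1 to compound 2 (within the scatter) lies within the scatter, so the two compounds cannot be ordered on these numbers.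

Compound 3 `COc1ccc(Cl)cc1C(=O)Nc1ccc(C2=NN(C(C)=O)C(c3ccccc3[N+](=O)[O-])C2)cc1` is not yet measured. It differs from compound 1 as follows: acetyl in place of hydrogen on an amine nitrogen in a ring. The difference is acetyl in place of hydrogen on an amine nitrogen in a ring of the shared core, with the 2-nitrophenyl group of compound 1 retained.

For the measured compounds named here, no measured step bears on this change. Going by the values given here, the only step available, a number 1.8 percentage points higher from compound 1 to compound 2 (within the scatter), concerns the nitrophenyl group on a saturated ring carbon and was within the scatter; it says nothing about replacing the hydrogen on the ring nitrogen by acetyl. For this assay the expectation is therefore that compound 3 stays near compound 1, with no step beyond the scatter in either direction, but the width of the range reflects the absence of any precedent.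

For compound 3 the estimated value in this assay is 80%, with a range from 62% to 92%. The step this estimate implies, a number 4.5 percentage points lower from compound 1 to compound 3 (within the scatter), is expected to lie within the scatter.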

Compound 3, a percentage reported as inhibition, in the whole organism at one dose (the size of the read-out at that dose, not a potency): 87.2%
Estimate against measurement, compound 3: 7.2 percentage points below; low and high end bracket the measured number.
By their numbers in this assay, from the lowest: compounds 1, 2 and 3 (each within the scatter of the next).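

At the amine nitrogen in the five-membered ring, the hydrogen of compound 1 can give way to acetyl with the read-out of this assay held: a number 2.7 percentage points higher from compound 1 to compound 3 (within the scatter). Compound 1 and compound 3 therefore cannot be ordered, but this position, two ring bonds from the ring atom that bears a large group and next to the ring atom that bears the 2-nitrophenyl group, accepts an acetyl group without a change that can be told from the scatter, at least in the presence of that 2-nitrophenyl group and at this single oral dose, where the read-out gives the size of the effect and not a potency. No measurement at hand offers a reason for this result.

Going by these compounds, it remains open whether acetyl on this nitrogen gives the same picture alongside the 4-nitrophenyl group of compound 2, and whether the position also accepts a different group, such as methyl, a longer acyl chain or a chain ending in a carboxylic acid. Lower doses would also be needed to show any difference between compound 1 and compound 3 that this read-out cannot resolve.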